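The compounds below may be only part of what the source reports. "The series", "measured", "known", "first", "only" and "open" are said of these compounds alone.

Measured compounds:
- compound 1, `O=C(/C(=C\c1ccc(Cl)cc1)Sc1ccc(Cl)cc1)c1ccc(Cl)cc1`, gives 1000 nM in a functional assay on DU-145 cells (Homo sapiens) for inhibition, read by trypan blue exclusion, with a stated time of 96 h; on this read-out higher numbers stand for weaker inhibition of growth and lower numbers for stronger inhibition of growth
- compound 2, `Cc1ccc(S/C(=C/c2ccc(Oc3ccccc3)cc2)C(=O)c2ccc(Cl)cc2)cc1`, gives 10000 nM in this assay

Going by the values given here, of the two numbers measured so far, compound 2 stands at the higher one; its nearest neighbour is compound 1, whose number is lower by a step beyond the usual scatter. The unmeasured compound 3, `Cc1ccc(S/C(=C/c2ccc(Cl)cc2)C(=O)c2ccc(Cl)cc2)cc1`, shares the aryl ketone and the tolylthio side of compound 2 and differs from it in one place: chloro in place of phenoxy on an aromatic carbon. That change makes the styryl end of compound 3 identical to the styryl end of compound 1, so the step from compound 2 to compound 3 in this assay is expected to go downward, toward stronger inhibition of growth, by an amount that is likely beyond the scatter but not the whole gap to compound 1. The expected step is a 4.0-fold lower number from compound 2 to compound 3 (0.60 log units; beyond the scatter). Compound 3 is therefore estimated at 2500 nM in this assay, with a range from 800 nM to 8000 nM.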

Compound 3, concentration for 50% growth inhibition: 10000 nM
Compound 3: the middle estimate sits 4.0-fold (0.60 log units) below what was measured; the whole stated range lies below it.
By their numbers in this assay, from the lowest: compound 1; then compounds 2 and 3 (each within the scatter of the next).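

In this assay, chloro in place of phenoxy on this aromatic carbon, para to a large group, gives a flat result (no change at the digits printed from compound 2 to compound 3 (within the scatter)), so with the methyl in place, the seven-atom phenoxy and the single chlorine are not told apart here. The earlier compounds shown here differed in more than one place and could not separate the two changes, but methyl in place of chloro on an aromatic carbon now shows a clear step on its own (a 10-fold higher number from compound 1 to compound 3 (1.00 log units; beyond the scatter)). Nothing available explains either result.

From the compounds shown here alone, it remains open whether phenoxy and chloro would also match each other with chloro rather than methyl at the other place. The compounds shown also leave open how an amine, a carboxylic acid or a methoxy group would fare on this aromatic carbon.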